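Fused triazole series: ethoxy to 1,1-difluoroethyl step

A few compounds are considered here, and "the series" means these few. Any claim that something is new, unique, unknown or untested is made for them only; others in the source may bear on it.

Measured so far in a physicochemical assay for lipophilicity, at pH 7.4; on this read-out higher numbers stand for higher lipophilicity and lower numbers for lower lipophilicity:
- compound 1 `Cc1cc(Nc2ccc(S(F)(F)(F)(F)F)cc2)n2nc(C3CC3)nc2n1` gives 3.5
- compound 2 `CCC(F)(F)c1nc2nc(C)cc(Nc3ccc(S(F)(F)(F)(F)F)cc3)n2n1` gives 3.9
- compound 3 `CCOc1nc2nc(C)cc(Nc3ccc(S(F)(F)(F)(F)F)cc3)n2n1` gives 3.4

Compound 3 sits lowest of the three numbers; compound 1 lies within the scatter of it, while compound 2 stands clearly higher, as a number 0.50 log units lower from compound 2 to compound 3 (beyond the scatter) shows. Compound 4 `Cc1cc(Nc2ccc(S(F)(F)(F)(F)F)cc2)n2nc(C(C)(F)F)nc2n1` is still to be measured in this assay. Its change from compound 3 is 1,1-difluoroethyl in place of ethoxy on an aromatic carbon.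

Within the data shown here, two measured steps bear on this. a number 0.50 log units lower from compound 2 to compound 3 (beyond the scatter) is the reverse direction of the present exchange, only with a chain one carbon longer entering. a number 0.40 log units higher from compound 1 to compound 2 (beyond the scatter) points the same way for the longer fluorinated chain. a number 0.10 log units lower from compound 1 to compound 3 (within the scatter) adds that ethoxy and cyclopropyl give about the same number. A rise from compound 3 is therefore expected in this assay, modest in size and probably somewhat smaller than the reverse of a number 0.50 log units lower from compound 2 to compound 3 (beyond the scatter) since the entering group is shorter; the expected step is a number 0.20 log units higher from compound 3 to compound 4 (within the scatter). Compound 4 is estimated at 3.6, with a range from 3.3 to 3.9.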

Compound 4, distribution coefficient: 3.6
For compound 4 middle estimate and measured number coincide at the digits printed, within the range that was stated.
By their numbers in this assay, from the lowest: compounds 3, 1, 4 and 2 (each within the scatter of the next, the first and the last beyond it).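

In this assay, 1,1-difluoroethyl in place of ethoxy, on an aromatic carbon between two ring nitrogen atoms, stays within the scatter (a number 0.20 log units higher from compound 3 to compound 4 (within the scatter)), as does 1,1-difluoroethyl in place of cyclopropyl (a number 0.10 log units higher from compound 1 to compound 4 (within the scatter)). 1,1-Difluoroethyl and 1,1-difluoropropyl also fall within the scatter of each other (a number 0.30 log units lower from compound 2 to compound 4 (within the scatter)), so compound 2 is separated from compounds 1 and 3 but not from compound 4, and compound 4 bridges the gap between them. No measurement at hand accounts for these steps.

Open, going by these compounds, is how far the number moves at this position with an amine, a carboxylic acid or trifluoromethyl. Also open, on these data alone, is what an unfluorinated propyl chain gives, which would pair directly with compound 2, and what a chain longer than 1,1-difluoropropyl gives.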